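Notes on removing the aryl ether in this series

A few compounds are considered here, and "the series" means these few. Any claim that something is new, unique, unknown or untested is made for them only; others in the source may bear on it.

Compound 1 `O=c1c(Cc2coc3cccc(OCC4CCCCC4)c3c2=O)coc2ccccc12`; compound 2 `CC(C)COc1cccc2occ(Cc3coc4ccccc4c3=O)c(=O)c12`; compound 3 `CC(C)CCOc1cccc2occ(Cc3coc4ccccc4c3=O)c(=O)c12`; compound 4 `O=c1c(Cc2coc3ccccc3c2=O)coc2ccccc12`, not yet measured.

In a functional assay on MDA-MB-231 cells (Homo sapiens) for antiproliferative activity, read by XTT assay (a higher number here means a weaker inhibitor, a lower number a stronger inhibitor), compound 1 gives 4110 nM. Compound 2 reaches only the assay limit of > 10000 nM. Compound 3 likewise returns only the limit of > 10000 nM (the limit of > 10000 nM in this assay, at which 2 of the 3 values shown sit), so it stands as a bound rather than a number. The step to compound 4 is hydrogen in place of isopentyloxy on an aromatic carbon. The measured steps that bear on it shrink the group on the ether carbon: an at least 2.4-fold higher number from compound 1 to compound 2 (0.38 log units; beyond the scatter) and an at least 2.4-fold higher number from compound 1 to compound 3 (0.38 log units; beyond the scatter), both weakening; a step that the two limits leave unreadable from compound 2 to compound 3 cannot be read. Among the measured compounds shown here, no measured step removes the ether outright, so the direction is not fixed by the set. Compound 4 is expected close to the same limit, with the expected step of an at least 1.1-fold lower number from compound 3 to compound 4 (0.04 log units; that floor lies within the scatter). The estimate for compound 4 is 9000 nM, range 2500 nM to 30000 nM.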

Compound 4, half-maximal inhibitory concentration: > 10000 nM
Compound 4 ended at the assay's limit; the forecaster's own chance of this, stated with the estimate: 50%; middle value at least 1.1-fold (0.04 log units) from the limit.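

Removing the ether outright, with hydrogen in place of cyclohexylmethoxy on the aromatic carbon, gives a readable loss in this assay (an at least 2.4-fold higher number from compound 1 to compound 4 (0.38 log units; beyond the scatter)). Compound 4 holds only a limit of the assay, and its steps from compound 2 and compound 3 cannot be read. Among the groups at this place, only cyclohexylmethoxy yields a number: the limit of > 10000 nM in this assay, at which 3 of the 4 values shown sit.

On these data alone, whether isobutoxy or isopentyloxy keeps any activity over hydrogen stays open. Also open, as far as these compounds go, is whether a benzyloxy group or a longer chain ending in an amine would improve on compound 1.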